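This account rests on a few compounds, and the source may have more. Where it says the series, first, only, none or still open, it means among the compounds named here.

The measured compounds in an assay on isolated protein for inhibition of Rho-associated protein kinase 1 (Homo sapiens), read by scintillation counting, radiometric assay and 33P incorporation, with a stated time of 40 min, in the presence of a further agent that is not named here; on this read-out lower numbers stand for stronger inhibition and higher numbers for weaker inhibition:

compound 1, `O=C(COc1ccc2c(=O)ccoc2c1)Nc1cccc(NC(=O)c2ccc(F)cc2)c1`: 129 nM
compound 2, `Cc1cc(C(=O)Nc2cccc(NC(=O)COc3ccc4c(=O)ccoc4c3)c2)no1`: 68 nM

Compound 2 carries the same core as compound 1, with the difference that a 1.9-fold lower number from compound 1 to compound 2 (0.28 log units; within the scatter). Its number and that of compound 1 therefore lie within the scatter of each other, so neither compound stands apart from the other on the two values at hand.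

Compound 3, `Cn1ccc(S(=O)(=O)Nc2cccc(NC(=O)COc3ccc4c(=O)ccoc4c3)c2)n1`, has not yet been measured in this assay. It differs from compound 2 in that (a group of 9 heavy atoms (4 carbon, 2 nitrogen, 2 oxygen, 1 sulfur; one five-membered aromatic ring with 2 hetero atoms) in place of a group of 8 heavy atoms (5 carbon, 1 nitrogen, 2 oxygen; one five-membered aromatic ring with 2 hetero atoms), on a nitrogen on an aromatic ring). For the measured compounds named here, the only measured step bearing on this position is the one from compound 1 to compound 2, and it did not reach beyond the scatter; it concerns a swap of one carbonyl-bound ring for another, whereas here the carbonyl itself gives way to a sulfonyl with a different ring. Going by the values given here, no measured pair covers that exchange, so the expectation rests on the one modest step alone and remains loose. Compound 3 is expected to come in near compound 2, with the step of a 1.8-fold higher number from compound 2 to compound 3 (0.25 log units; within the scatter) foreseen as no more than a shift within or just beyond the scatter. The estimate for compound 3 in this assay is 120 nM, with a range from 40 nM to 400 nM.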

Compound 3, half-maximal inhibitory concentration: > 10000 nM
Compound 3: only a limit was reported; the forecaster's own chance of this, stated with the estimate: 5%; middle value at least 83-fold (1.92 log units) from the limit.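

The value of compound 3 in this assay is a limit and not a number: the limit of > 10000 nM in this assay, at which 1 of the 3 values shown sits.

At this place, on a nitrogen on an aromatic ring, giving up the (5-methyl-1,2-oxazol-3-yl)carbonyl group for the sulfonyl group with its five-membered aromatic ring brings an at least 140-fold higher number from compound 2 to compound 3 (2.16 log units; beyond the scatter), and the exchange for the 4-fluorophenyl carbonyl group brings an at least 77-fold higher number from compound 1 to compound 3 (1.88 log units; beyond the scatter). For the compounds shown here, the earlier swap of one carbonyl-bound ring for another gave only a 1.9-fold lower number from compound 1 to compound 2 (0.28 log units; within the scatter), so the new steps, both beyond the scatter, show for the first time that this position does not accept every change.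

The sulfonyl and the ring change together in compound 3, so the compounds shown cannot tell which of the two goes with the loss of inhibition, and a sulfonyl carrying the 4-fluorophenyl ring or a carbonyl carrying the ring of compound 3 would separate them. Also open, going by these compounds, is how a small methylsulfonyl group, or a carbonyl bearing an open alkyl chain or an amine in place of any ring, would read at this place.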